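Piperazine series, adenosine A3 displacement at single concentration

This account rests on a few compounds, and the source may have more. Where it says the series, first, only, none or still open, it means among the compounds named here.

Measured so far:
- compound 1 `Nc1scc(CN2CCN(c3ccncc3)CC2)c1C(=O)c1ccc(Cl)cc1`: 2%
- compound 2 `Nc1scc(CN2CCN(c3ccc(C(F)(F)F)cc3)CC2)c1C(=O)c1cccc(C(F)(F)F)c1`: 0%
- compound 3 `Nc1scc(CN2CCN(c3c(F)cccc3F)CC2)c1C(=O)c1cccc(C(F)(F)F)c1`: 0%

In an assay on CHO cells for displacement of a labelled ligand from adenosine receptor A3 (Homo sapiens), read by scintillation counting, with a stated time of 120 min, tested at 10 uM (a higher number here means more inhibition at the concentration tested (going by the name of the read-out), a lower number less inhibition), compound 1 gives 2%. Compound 2 and compound 3 each sit within the scatter of compound 1, so none of the three separates from the others; all three show essentially no displacement at this concentration. Among the measured compounds shown here, the one measured step, no change at the digits printed from compound 2 to compound 3 (within the scatter), exchanges one aryl group for another on the ring nitrogen and leaves the read-out unchanged.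

Compound 4 `Nc1scc(CN2CCN(CCCc3ccc(Cl)cc3)CC2)c1C(=O)c1ccc(Cl)cc1` is not yet measured. It differs from compound 1 by 3-(4-chlorophenyl)propyl in place of pyridin-4-yl on an amine nitrogen in a ring. For the measured compounds named here, no measured step bears directly on this exchange; the only step at the same position stayed within the scatter, and every compound shown sits near zero. The expected step is therefore a number 1 percentage points higher from compound 1 to compound 4 (within the scatter), none beyond the scatter. Compound 4 is estimated at 3%, range -8% to 15%.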

Compound 4, a percentage reported as inhibition, at one concentration (the size of the read-out at that concentration, not a potency): 0%
Compound 4: middle estimate off by 3 percentage points, on the high side; the range from low to high includes it.
By their numbers in this assay, from the lowest: compounds 2, 3, 4 and 1 (each within the scatter of the next).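

In this assay, among the compounds shown here, the exchange of pyridin-4-yl for 3-(4-chlorophenyl)propyl gives a number 2 percentage points lower from compound 1 to compound 4 (within the scatter) and extends the earlier reading to a group on a propyl chain, whereas the earlier compounds carry aromatic rings directly on the amine nitrogen in a ring. Neither the loss of the ring hetero atom nor the larger group, with 10 heavy atoms against 6, separates compound 4 from compound 1. No supporting data bear on this result.

Going by these compounds, whether an amine or a carboxylic acid on a longer chain at this nitrogen would give measurable displacement remains open. Also open, on these data alone, is whether any group at this position can do so on the shared core.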